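A few compounds are considered here, and "the series" means these few. Any claim that something is new, unique, unknown or untested is made for them only; others in the source may bear on it.

Going by the values given here, in an ADME assay on Huh-7 cells (Homo sapiens) for cytotoxicity, with a stated time of 3 days (a lower number here means that less compound is tolerated, a higher number that more compound is tolerated), compound 3 `O=C(NC1CCCCC1)c1c(NO)cc(-c2ccc(F)cc2)oc1=O` gives 11400 nM as the only actual number so far. Compound 1 `O=C(Nc1cc([N+](=O)[O-])ccc1O)c1c(NO)cc(-c2ccccc2)oc1=O` reads > 20000 nM and this is a limit of the assay. Compound 2 `O=C(NC1CC1)c1c(NO)cc(-c2ccc(F)cc2)oc1=O` reads > 20000 nM and this too is a limit. Compound 4 `COc1ccc(-c2cc(NO)c(C(=O)NC3CCCCC3)c(=O)o2)cc1` keeps the cyclohexyl amide of compound 3 and changes one group: methoxy in place of fluoro on an aromatic carbon that is, methoxy in place of fluoro on an aromatic carbon, para to a large group. Among the compounds with values here, the only measured step of an at least 1.7-fold lower number from compound 2 to compound 3 (0.24 log units; that floor lies within the scatter) lies on the amide nitrogen and not on this ring, so it offers little guidance here. No step beyond the scatter is therefore expected in this assay. Compound 3 at 11400 nM stays the anchor. The expected step is a 1.1-fold higher number from compound 3 to compound 4 (0.02 log units; within the scatter) with no direction favoured. For compound 4 the estimate is 12000 nM with 6000 nM to 20000 nM as its expected range.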

Compound 4, half-maximal cytotoxic concentration: 13900 nM
Estimate against measurement, compound 4: 1.2-fold (0.06 log units) below; low and high end bracket the measured number.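

Going by these compounds alone, the step of a 1.2-fold higher number from compound 3 to compound 4 (0.09 log units; within the scatter) is the first read in this assay on the aromatic ring rather than on the amide nitrogen. Methoxy in place of fluoro at this position therefore gives no ranking of compound 3 against compound 4, and the shift stays within the usual scatter. Not far beyond these numbers, the readings become a limit of the assay: the limit of > 20000 nM in this assay, at which 2 of the 4 values shown sit. Going by these compounds, whether an amine or a carboxylic acid at this position would move the number beyond the scatter stays open. So does whether methoxy would behave alike with the cyclopropyl amide of compound 2.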